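The source may hold more compounds than are shown below. What is called first, only, known or untested is meant among the compounds shown, and "the series" means these compounds.

In a functional assay on HCT-116 cells (Homo sapiens) for inhibition, read by sulforhodamine B assay, with a stated time of 48 h (a higher number here means a weaker inhibitor of growth, a lower number a stronger inhibitor of growth), compound 1 (`O=C(Nc1cccc(-n2cc(-c3ccncc3)c(-c3ccc(Cl)c(O)c3)n2)c1)Nc1cccc(C(F)(F)F)c1`) gives 8260 nM and compound 2 (`COc1cc(-c2nn(-c3cccc(NC(=O)Nc4cccc(C(F)(F)F)c4)c3)cc2-c2ccncc2)ccc1Cl`) gives 7170 nM. These two numbers lie within the scatter of each other, so compound 2 stands level with compound 1 and neither can be ranked above the other. Compound 3 (`COc1cc(-c2nn(-c3cccc(NC(=O)c4ccccc4)c3)cc2-c2ccncc2)ccc1Cl`) differs from compound 2 in one place: phenyl in place of (3-(trifluoromethyl)phenyl)amino on a carbonyl carbon. Among the measured compounds shown here, the only measured step is a 1.2-fold lower number from compound 1 to compound 2 (0.06 log units; within the scatter). It swaps methyl for hydrogen on an oxygen on an aromatic ring, lies within the scatter and concerns a different place, so it gives only weak guidance here. For the measured compounds named here, no measured step covers the new change, which leaves the direction uncertain. A modest move towards a higher number in this assay is expected, namely a 1.5-fold higher number from compound 2 to compound 3 (0.19 log units; within the scatter). Compound 3 is estimated at 11000 nM, with an expected range of 4500 nM to 30000 nM.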

Compound 3, concentration for total growth inhibition: > 100000 nM
Compound 3: only a limit was reported; the forecaster's own chance of this, stated with the estimate: 20%; middle value at least 9.0-fold (0.95 log units) from the limit.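

Among the compounds shown here, on this carbonyl carbon the group matters far more than the earlier compounds could show: phenyl in place of (3-(trifluoromethyl)phenyl)amino gives an at least 13-fold higher number from compound 2 to compound 3 (1.14 log units; beyond the scatter), whereas the only earlier step, made at another place on the molecule, was a 1.2-fold lower number from compound 1 to compound 2 (0.06 log units; within the scatter). For compound 3, the reading in this assay is a limit and not a number: the limit of > 100000 nM in this assay, at which 1 of the 3 values shown sits. The true size of the step is therefore unknown, and the change removes several things at once, as the departing group has one hydrogen-bond donor and phenyl has none.

The compounds shown leave open whether the amide-type nitrogen's added amino link or the trifluoromethyl group matters more. A plain phenylamino group on the same carbonyl carbon would separate the two, and a 3-chlorophenylamino group would test whether another group can stand in for trifluoromethyl.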